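Nitro to amino on the terminal ring: compound 4

This account rests on a few compounds, and the source may have more. Where it says the series, first, only, none or still open, it means among the compounds named here.

Measured so far in a physicochemical assay for lipophilicity; on this read-out lower numbers stand for lower lipophilicity and higher numbers for higher lipophilicity:
compound 1 `CCOC(=O)C1=C(C)NC(=S)NC1c1cn(C(=O)CNc2ccc([N+](=O)[O-])c(Cl)c2)c2ccccc12` gives 3.4
compound 2 `CCOC(=O)C1=C(C)NC(=O)NC1c1cn(C(=O)CNc2ccc([N+](=O)[O-])cc2Cl)c2ccccc12` gives 1.99
compound 3 `CCOC(=O)C1=C(C)NC(=O)NC1c1cn(C(=O)CNc2ccccc2[N+](=O)[O-])c2ccccc12` gives 1.48

Compound 3 stands lowest of the three numbers in this assay. Its nearest neighbour is compound 2, and the gap is the measured step of a number 0.51 log units lower from compound 2 to compound 3 (beyond the scatter), which lies beyond the scatter. Among the compounds with values here, compound 1, which carries a thiocarbonyl where compounds 2 and 3 carry a carbonyl in the shared core, sits well above both, but no single-point step connects it to compound 3, so only the two values themselves can be compared.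

Compound 4 `CCOC(=O)C1=C(C)NC(=O)NC1c1cn(C(=O)CNc2ccccc2N)c2ccccc12` differs from compound 3 in one place: amino in place of nitro on an aromatic carbon. Within the data shown here, none of the measured steps covers this change. Among the measured compounds shown here, the only single-point step in the set, a number 0.51 log units lower from compound 2 to compound 3 (beyond the scatter), concerns a different exchange on the same terminal ring and gives no direct guide to the nitro-to-amino swap; it shows only that this ring position is a place where the number in this assay moves by a modest amount.

The working expectation is a step downward, beyond the scatter. Compound 4 is expected to give 0.7 in this assay, estimated between 0.1 and 1.3. The expected step is a number 0.78 log units lower from compound 3 to compound 4 (beyond the scatter).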

Compound 4, partition coefficient: 0.74
Estimate against measurement, compound 4: 0.04 log units below; low and high end bracket the measured number.
By their numbers in this assay, from the lowest: compound 4; then compound 3; then compound 2; then compound 1.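

In this assay, the exchange of nitro for amino on an aromatic carbon, ortho to a large group, gives a clear change at a place where the earlier compounds had shown only the effect of altering the rest of the aryl group: a number 0.74 log units lower from compound 3 to compound 4 (beyond the scatter). Read against compound 2, the full replacement of 2-chloro-4-nitrophenyl by 2-aminophenyl gives a number 1.25 log units lower from compound 2 to compound 4 (beyond the scatter) and is a large step, whereas a number 0.51 log units lower from compound 2 to compound 3 (beyond the scatter) was only modest, so changes to this aryl group now span a wider range of the read-out than the first three compounds suggested. The compounds shown offer no measurement that accounts for the size of either new step.

From the compounds shown here alone, whether the same exchange of nitro for amino gives a step of similar size with a chlorine retained on the ring, or on the thiocarbonyl core of compound 1, remains open. Also open, going by these compounds, is how other groups on the same aromatic carbon would read in this assay, for example a hydroxyl, an acetamide or a carboxylic acid.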